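Swapping dimethoxyphenyl isomers in the growth-inhibition series

The source may hold more compounds than are shown below. What is called first, only, known or untested is meant among the compounds shown, and "the series" means these compounds.

In a functional assay on A549 cells (Homo sapiens) for inhibition, read by sulforhodamine B assay, with a stated time of 48 h (a higher number here means a weaker inhibitor of growth, a lower number a stronger inhibitor of growth), compound 1 `COc1cc(/C=C/C(=O)/C=C/c2sccc2C)cc(OC)c1OC` gives 9310 nM while compound 2 `COc1ccc(/C=C/C(=O)C(=Cc2cccc(F)c2)C(=O)/C=C/c2ccc(OC)c(OC)c2)cc1OC` gives 580 nM and compound 3 `COc1ccc(OC)c(C=C(C(=O)/C=C/c2ccc(O)c(OC)c2)C(=O)/C=C/c2ccc(O)c(OC)c2)c1` gives 670 nM. Compound 3 therefore stands within the scatter of compound 2 and well under compound 1.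

Compound 4 `COc1cc(/C=C/C(=O)C(=Cc2ccc(OC)c(OC)c2)C(=O)/C=C/c2ccc(O)c(OC)c2)ccc1O` has the same atoms as compound 3, joined differently (3,4-dimethoxyphenyl in place of 2,5-dimethoxyphenyl on a double-bonded chain carbon bound to a double-bonded chain carbon). It carries 3,4-dimethoxyphenyl in place of 2,5-dimethoxyphenyl on a double-bonded chain carbon bound to a double-bonded chain carbon.

Going by the values given here, no measured pair differs in one place only, so there is no direct precedent for this step. Compound 2 at 580 nM and compound 3 at 670 nM differ in this group and elsewhere, yet their values lie within the scatter of each other. On that basis, no change beyond the scatter is expected in this assay. The estimated step is a 1.1-fold lower number from compound 3 to compound 4 (0.05 log units; within the scatter) and has no clear direction. The estimate for compound 4 is 600 nM (expected range 250 nM to 1500 nM).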

Compound 4, concentration for 50% growth inhibition: 430 nM
Estimate against measurement, compound 4: 1.4-fold (0.14 log units) above; low and high end bracket the measured number.
By their numbers in this assay, from the lowest: compounds 4, 2 and 3 (each within the scatter of the next); then compound 1.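

In this assay, the series gains its first comparison differing in one place: 3,4-dimethoxyphenyl in place of 2,5-dimethoxyphenyl on a double-bonded chain carbon bound to a double-bonded chain carbon gives a 1.6-fold lower number from compound 3 to compound 4 (0.19 log units; within the scatter) and so shows no separation between the two isomers. With the rest of the structure held constant, this read-out does not distinguish these two dimethoxyphenyl groups at this place. No available measurement offers an explanation for this result.

On these data alone, only these two dimethoxyphenyl groups can be compared directly here, so it remains open whether a group of another kind at this place, such as a carboxylic acid or an amine, would move the number beyond the scatter. As far as these compounds go, whether the swap reads the same with other end groups on the shared core also remains open.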